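The source may report more compounds than this note shows. Statements on the series, on what has been measured and on what is new or still open speak of the compounds shown alone.

In an ADME assay on microsomes from liver (Homo sapiens) for metabolic stability, with a stated time of 10 min (a lower number here means that less of the compound is left, a higher number that more of the compound is left), compound 1 (`Cc1nc2c(cc1Nc1nc(Cl)cn([C@H](C)C3CC3)c1=O)COC2`) stands as "not determined" (no result reported). Compound 2 (`COc1nc(C)c(Nc2nc(Cl)cn([C@H](C)C3CC3)c2=O)c(OC)n1`) gives 81%. Compound 3 (`COC[C@@H](C1CC1)n1cc(Cl)nc(Nc2c(C)nc(OC)nc2OC)c1=O`) gives 25%, the lower of the two numbers available. Compound 4 (`COC[C@H](C1CC1)n1cc(Cl)nc(Nc2c(C)nc(OC)nc2OC)c1=O`) changes compound 3 as follows: the two compounds have the same atoms and bonds and differ only in configuration as drawn: 1 of 1 stereo elements differ; a stereocentre at a saturated chain carbon is drawn R in compound 3 and S in compound 4. Going by the values given here, the only measured step bearing on this is a number 56 percentage points lower from compound 2 to compound 3 (beyond the scatter), which is large, but it swaps the group on an aromatic nitrogen rather than its configuration. Among the compounds with values here, no measured pair shows the size of a configuration change alone. Compound 4 keeps the 1-cyclopropyl-2-methoxyethyl group of compound 3, so a result near 25% is expected, with no step beyond the scatter. The expected change is a number 5 percentage points higher from compound 3 to compound 4 (within the scatter), with little confidence in its direction. For compound 4 the estimate is 30%, with an expected range of 10% to 60%.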

Compound 4, percent of the compound remaining: 18%
Beside the measured number, compound 4's estimate is 12 percentage points above it; low and high end bracket the measured number.
By their numbers in this assay, from the lowest: compounds 4 and 3 (each within the scatter of the next); then compound 2.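

In this assay the inverted stereocentre gives a number 7 percentage points lower from compound 3 to compound 4 (within the scatter) and does not separate the two forms, a reading that isolates configuration alone: the fact that compounds 3 and 4 differ only in the configuration as drawn. Methoxy on the chain goes with a number 63 percentage points lower from compound 2 to compound 4 (beyond the scatter) as well, so the large drop seen with one configuration holds with the other.

Open, going by these compounds, is whether a hydroxyl, a fluorine or a dimethylamino group on this chain carbon gives numbers as low as methoxy does. Also open, on these data alone, is how the 1-cyclopropylethyl group responds to inversion of its own stereocentre.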